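Methyl Scan on Two Aryl-Thiophene Acrylamide Cores

The source may hold more compounds than are shown below. What is called first, only, known or untested is meant among the compounds shown, and "the series" means these compounds.

Three compounds have numbers in a functional assay on HeLa cells (Homo sapiens) for cytotoxicity, read by CCK-8 assay, with a stated time of 24 h; on this read-out higher numbers stand for weaker inhibition and lower numbers for stronger inhibition. Compound 1 `C/C(=C\c1cc(-c2ccccc2)cs1)C(N)=O` gives 12700 nM. Compound 2 `C/C(=C\c1nc(-c2ccccc2)cs1)C(N)=O` gives 2770 nM; the difference between the two cores is not broken down here. Compound 3 `C/C(=C\c1nc(-c2ccc(C)cc2)cs1)C(N)=O` gives 25000 nM. Among the compounds with values here, the one counted change, (methyl in place of hydrogen on an aromatic carbon), made a step of a 9.0-fold higher number from compound 2 to compound 3 (0.96 log units; beyond the scatter).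

Compound 4 `C/C(=C\c1cc(-c2ccccc2C)cs1)C(N)=O` is not yet measured. It carries the same kind of change on the core of compound 1, (methyl in place of hydrogen on an aromatic carbon), but the methyl is ortho to a large group here rather than para to a large group. Within the data shown here, the step from compound 1 to compound 4 in this assay is expected to be a 2.8-fold higher number from compound 1 to compound 4 (0.44 log units; beyond the scatter), a smaller move than the earlier one because the place differs and only one step, a 9.0-fold higher number from compound 2 to compound 3 (0.96 log units; beyond the scatter), is known. Compound 4 is estimated at 35000 nM, between 10000 nM and 100000 nM.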

Compound 4, half-maximal inhibitory concentration: 19400 nM
Beside the measured number, compound 4's estimate is 1.8-fold (0.26 log units) above it; the measured number falls inside the stated range.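

The same change does not carry over at the same size between the two cores in this assay: the same change on two cores in this assay, a 9.0-fold higher number (0.96 log units; beyond the scatter) from compound 2 to compound 3 and a 1.5-fold higher number (0.18 log units; within the scatter) from compound 1 to compound 4, 5.9-fold (0.77 log units) apart, beyond the scatter of two such steps

On the core of compound 1, the methyl ortho to a large group gives a 1.5-fold higher number from compound 1 to compound 4 (0.18 log units; within the scatter), so this single step shows no measurable effect of the change on that core. The two steps differ in both the core and the place of the methyl, so the gap between them cannot be assigned to either difference, and the result sets no general rule for moving this change between cores.

On these data alone, it remains open whether a methyl at one matching place on both cores would give steps of similar size. Also open, as far as these compounds go, is how other groups on the six-membered aromatic ring, such as a methoxy group, a fluorine or a carboxylic acid, would behave on each core.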